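The source may hold more compounds than are shown below. What is called first, only, known or untested is meant among the compounds shown, and "the series" means these compounds.

Measured so far:

Compound 1, `CCN(CC)S(=O)(=O)c1ccc(S(=O)(=O)N2CCC[C@@H](C(=O)NC3CN(C(=O)OC(C)(C)C)C3)C2)cc1`, in a functional assay on MIA PaCa-2 cells (Homo sapiens) for inhibition, read by MTT assay, with a stated time of 3 days (a lower number here means a stronger inhibitor, a higher number a weaker inhibitor), compound 1 gives 100 nM.
Compound 2, `CC(C)c1noc(N2CCN(C(=O)[C@@H]3CCCN(S(=O)(=O)c4ccc(S(=O)(=O)C(C)C)cc4)C3)CC2)n1`, in this assay compound 2 gives 30 nM.
Compound 3, `CCOC(=O)[C@@H]1CCCN(S(=O)(=O)c2ccc(S(=O)(=O)N(CC)CC)nc2)C1`, in this assay compound 3 gives 1600 nM.

Among these three numbers compound 1 stands second highest. Compound 2 sits below it by a margin that goes beyond the usual scatter, so compound 2 reads as the stronger inhibitor of the two. Compound 3 sits well above compound 1, again beyond the scatter, and is the weakest of the three in this assay.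

The step in view leads from compound 1 to compound 4, `CCN(CC)S(=O)(=O)c1ccc(S(=O)(=O)N2CCC[C@@H](C(=O)NC3CN(C(=O)C4CC4)C3)C2)cc1`, which has not yet been measured. The two structures differ in one place: cyclopropyl in place of tert-butoxy on a carbonyl carbon. The rest of the molecule, including the shared core and the sulfonyl-bearing ring, stays unchanged.

Among the compounds with values here, no measured pair here carries the same change, so there is no direct precedent for its size. The swap replaces one small group on the azetidine nitrogen with another small group of similar bulk, and it removes one hydrogen-bond acceptor. Such a change is expected to move the number only a little, if at all, in this assay; the step from compound 1 to compound 4 is estimated at a 1.2-fold higher number from compound 1 to compound 4 (0.08 log units; within the scatter), which lies within the scatter. For compound 4 the expected value is 120 nM, with a likely range from 40 nM to 350 nM.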

Compound 4, half-maximal inhibitory concentration: 3100 nM
Beside the measured number, compound 4's estimate is 26-fold (1.41 log units) below it, outside the stated range (above it).
By their numbers in this assay, from the lowest: compound 2; then compound 1; then compounds 3 and 4 (each within the scatter of the next).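

In this assay, the group on this carbonyl carbon proves to matter a great deal: cyclopropyl in place of tert-butoxy gives a 31-fold higher number from compound 1 to compound 4 (1.49 log units; beyond the scatter), a large loss of inhibition from a single change. Within the data shown here, this is the first step between measured compounds that differ in only one place, and it shows that this position does not accept every small group equally. Nothing shown here gives a reason for the loss.

As far as these compounds go, it remains open whether tert-butyl set directly on the carbonyl carbon, or a cyclopropoxy group, would keep the number near that of compound 1 or leave it near that of compound 4. Such groups would help show whether the oxygen or the rest of the tert-butoxy group goes with the stronger inhibition.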